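This account rests on a few compounds, and the source may have more. Where it says the series, first, only, none or still open, it means among the compounds named here.

The measured compounds are:
compound 1, `Nc1nc(Cl)c2ncn(Cc3ccccc3CCl)c2n1`, which in a functional assay on NCI-H322M cells (Homo sapiens) for cytotoxicity, read by sulforhodamine B assay, with a stated time of 48 h (a higher number here means a weaker inhibitor of growth, a lower number a stronger inhibitor of growth), gives 29500 nM;
compound 2, `ClCc1cccc(Cn2cnc3nc(Cl)nc(Cl)c32)c1`, which gives 26900 nM;
compound 3, `Nc1nc(Cl)c2ncn(Cc3cccc(CCl)c3)c2n1`, which gives 22400 nM.

Among these three numbers compound 1 has the highest, but its gap to compound 2 and its gap to compound 3 both lie within the usual scatter of repeated measurements, so the three compounds cannot be told apart on these data. All three are weak inhibitors of growth in this assay, and none stands out.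

Compound 4, `ClCc1ccccc1Cn1cnc2c(Cl)ncnc21`, has not yet been tested. It differs from compound 1 in one place: hydrogen in place of amino on an aromatic carbon. Within the data shown here, no pair of measured compounds isolates this change, so its effect is unknown here. What the data do show is that compound 2, which also lacks the amino group, sits within the scatter of compound 1, and that every change made so far among these compounds has left the numbers within the scatter. On that basis the step expected in this assay, a 1.0-fold higher number from compound 1 to compound 4 (0.01 log units; within the scatter), is none beyond the scatter, in either direction. Compound 4 is therefore estimated at 30000 nM, with a range from 12000 nM to 75000 nM.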

Compound 4, concentration for total growth inhibition: 13800 nM
For compound 4 the middle estimate is 2.2-fold (0.34 log units) above the measured one; low and high end bracket the measured number.
By their numbers in this assay, from the lowest: compounds 4, 3, 2 and 1 (each within the scatter of the next, the first and the last beyond it).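

Among these compounds, putting hydrogen in place of amino on this aromatic carbon, between two ring nitrogen atoms, is the first change to move a number beyond the scatter: in this assay the result is a 2.1-fold lower number from compound 1 to compound 4 (0.33 log units; beyond the scatter), a modest step towards stronger inhibition of growth. The amino group at this position is therefore not needed for the activity of compound 1 in this assay, and its removal gives a small gain, although this rests on a single pair and the number remains that of a weak inhibitor. Nothing in the data offers a cause for this step.

As far as these compounds go, whether the same change would have the same effect on the core of compound 3, where the chloromethyl group stands elsewhere on the benzene ring, remains open. It is also open how this carbon would respond to a group other than hydrogen or amino, such as a methyl, a methoxy, a dimethylamino or a fluoro group, none of which is among the compounds shown.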